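Swapping an aryloxy chain for a cyclohexyl tail

This account rests on a few compounds, and the source may have more. Where it says the series, first, only, none or still open, it means among the compounds named here.

Measured so far:
Compound 1 `COc1ccc(OCCCCCN2CCCC(COC(=O)c3ccccc3N3C(=O)CC(C)C3=O)C2)cc1OC` gives 2000000 nM in an in vitro functional assay on HEK ts201 cells for antagonist activity at Neuronal acetylcholine receptor; alpha3/beta4 (Homo sapiens), read by fluorescence and calcium flux; on this read-out lower numbers stand for stronger inhibition and higher numbers for weaker inhibition.
Compound 2 `CC1CC(=O)N(c2ccccc2C(=O)OCC2CCCN(CCCCOc3ccc(Cl)c(Cl)c3)C2)C1=O` gives 74100 nM in this assay.

Of the two measured compounds, compound 2 has the lower number, and the gap to compound 1 is described by a 27-fold lower number from compound 1 to compound 2 (1.43 log units; beyond the scatter), a change in the group that hangs from the saturated chain attached to the ring amine nitrogen.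

Compound 3 `CC1CC(=O)N(c2ccccc2C(=O)OCC2CCCN(CCCC3CCCCC3)C2)C1=O` has not yet been measured. It differs from compound 2 in this way: cyclohexyl in place of (3,4-dichlorophenoxy)methyl on a saturated chain carbon, three bonds along the chain from an amine nitrogen in a ring. So the aromatic ring with its two chlorine atoms and the ether oxygen disappear, and a plain saturated ring sits on a chain that is one bond shorter.

Among the measured compounds shown here, only one measured step exists, and it concerns a different kind of change, an exchange of one substituted phenoxy group for another. It shows that this end of the molecule matters a great deal, but it says nothing directly about removing the aromatic ring and the oxygen. With so little to go on, the most cautious expectation is a weaker inhibition than compound 2, with a wide range.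

Compound 3 is estimated at 200000 nM in this assay, within 40000 nM to 1000000 nM, which would correspond to an expected step of a 2.7-fold higher number from compound 2 to compound 3 (0.43 log units; beyond the scatter).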

Compound 3, half-maximal inhibitory concentration: 10700 nM
Beside the measured number, compound 3's estimate is 19-fold (1.27 log units) above it; measured number outside the range, below it.
By their numbers in this assay, from the lowest: compound 3; then compound 2; then compound 1.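

Within the series shown, the tail on the ring amine nitrogen does not need an aromatic ring, an ether oxygen or chlorine atoms to give inhibition in this assay. Cyclohexyl in place of (3,4-dichlorophenoxy)methyl, on a saturated chain carbon three bonds along the chain from the ring amine nitrogen, gives a 6.9-fold lower number from compound 2 to compound 3 (0.84 log units; beyond the scatter) and leaves compound 3 with the lowest number of the three, even though the group that enters has fewer heavy atoms than the one that leaves. The earlier step (a 27-fold lower number from compound 1 to compound 2 (1.43 log units; beyond the scatter)) compared only two tails that both carried a substituted phenoxy group, so it could not show that a purely saturated carbon ring is tolerated here, and nothing measured alongside these numbers accounts for the new step.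

Because the aromatic ring, the oxygen, the chlorine atoms and the chain length all change together in this one step, the effect of each remains unseparated. A plain phenyl or a cyclohexyloxy group on the same chain would help to pull these apart, and a longer chain carrying cyclohexyl would test how far the ring should sit from the amine nitrogen.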